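A Second Isopropyl Group Tested on a Chloro Analogue

The source may hold more compounds than are shown below. What is called first, only, known or untested is meant among the compounds shown, and "the series" means these compounds.

Compound 1 `Cc1ccc(-c2csc(NC(=O)COc3ccccc3)n2)cc1`: 43000 nM
Compound 2 `Cc1ccc(-c2csc(NC(=O)COc3ccccc3C(C)C)n2)cc1`: 49200 nM
Compound 3 `CC(C)c1ccccc1OCC(=O)Nc1nc(-c2ccc(Cl)cc2)cs1`: 18700 nM

The three measured compounds were examined in a functional assay on MCF7 cells (Homo sapiens) for cytotoxicity, read by MTT assay, with a stated time of 48 h; a lower number here means a stronger inhibitor, a higher number a weaker inhibitor. Compound 1 gives 43000 nM, and the change from compound 1 to compound 2, (isopropyl in place of hydrogen on an aromatic carbon), produces a 1.1-fold higher number from compound 1 to compound 2 (0.06 log units; within the scatter). The next change gives a 2.6-fold lower number from compound 2 to compound 3 (0.42 log units; beyond the scatter), leaving compound 3 with the lowest number of the three. The difference between the core of compound 1 and that of compound 3 is not broken down here.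

Compound 4 `CC(C)c1ccc(OCC(=O)Nc2nc(-c3ccc(Cl)cc3)cs2)c(C(C)C)c1` has not yet been measured. It differs from compound 3 by isopropyl in place of hydrogen on an aromatic carbon. The surroundings differ from the earlier case: in compound 2 the entering group is ortho to a large group, whereas in compound 4 it is meta to an isopropyl group and para to a large group, so this is the same kind of change rather than the same change. The expected step is a 1.1-fold higher number from compound 3 to compound 4 (0.03 log units; within the scatter), which rests on the earlier 1.1-fold higher number from compound 1 to compound 2 (0.06 log units; within the scatter) lying within the scatter. Compound 4 is therefore estimated at 20000 nM, between 9000 nM and 45000 nM.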

Compound 4, half-maximal inhibitory concentration: 40100 nM
For compound 4 the middle estimate is 2.0-fold (0.30 log units) below the measured one, and the stated range covers the measured number.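

In this assay, isopropyl in place of hydrogen on an aromatic carbon gave a 2.1-fold higher number from compound 3 to compound 4 (0.33 log units; beyond the scatter). Set beside the earlier case, this step does not differ from it by more than the scatter of two such steps allows, so the data show no detectable dependence of this change on the core: the same change on two cores in this assay, a 1.1-fold higher number (0.06 log units; within the scatter) from compound 1 to compound 2 and a 2.1-fold higher number (0.33 log units; beyond the scatter) from compound 3 to compound 4, 1.9-fold (0.27 log units) apart, within the scatter of two such steps

Going by these compounds alone, this does not show that the change behaves alike on every core, since only two steps are available and the entering group stands in a different place in each: in compound 4 it is meta to an isopropyl group and para to a large group, so any effect of the core cannot be separated from an effect of position.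

Going by these compounds, what a methoxy group or an amine would do in place of the second isopropyl group remains open. So does whether the step would hold on a core carrying neither the methyl nor the chloro group.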